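Swapping a chloro for a methoxy on the outer phenyl ring

The source may hold more compounds than are shown below. What is called first, only, known or untested is meant among the compounds shown, and "the series" means these compounds.

Measured so far:
- compound 1, `O=C1NC(=O)/C(=C/c2ccc(OCCSc3nnc(-c4ccccc4[N+](=O)[O-])[nH]3)cc2)S1`: 49.1%
- compound 2, `O=C1NC(=O)/C(=C/c2ccc(OCCSc3nnc(-c4ccc(Cl)cc4)[nH]3)cc2)S1`: 41.6%

Both compounds were tested in a functional assay on the whole organism (strain Wistar) with Rattus norvegicus as the target, with a stated time of 15 days, at a dose of 100 mg/kg by the oral route; on this read-out higher numbers stand for a stronger effect at the one dose given and lower numbers for a weaker effect. Compound 1, carrying a 2-nitrophenyl on the shared core, gives 49.1%. Compound 2, with a 4-chlorophenyl in place of that 2-nitrophenyl, gives 41.6%. The two numbers sit close together: the step of a number 7.5 percentage points lower from compound 1 to compound 2 (within the scatter) stays within the usual scatter of repeated measurements, so the data do not separate compound 1 from compound 2.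

Compound 3, `COc1ccc(-c2nnc(SCCOc3ccc(/C=C4\SC(=O)NC4=O)cc3)[nH]2)cc1`, has not yet been measured. It differs from compound 2 in one place: methoxy in place of chloro on an aromatic carbon. Seen one bond further out, this reads 4-chlorophenyl to 4-methoxyphenyl.

Within the data shown here, the only step that bears on this change is the one from compound 1 to compound 2, which also altered the group on this phenyl ring and moved the read-out by a number 7.5 percentage points lower from compound 1 to compound 2 (within the scatter), within the scatter. On that basis, the step of a number 1.4 percentage points higher from compound 2 to compound 3 (within the scatter) is expected to stay within the scatter as well. Compound 3 is therefore estimated at 43%, with a range from 28% to 58%.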

Compound 3, a percentage reported as activity, at one dose (the size of the read-out at that dose, not a potency): 71.2%
The estimate for compound 3 lay 28.2 percentage points below the measured number; measured number above the stated range.
By their numbers in this assay, from the lowest: compounds 2 and 1 (each within the scatter of the next); then compound 3.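

In this assay, the group on the outer phenyl ring can clearly change the result: with methoxy in place of chloro, para to a large group, the data show a number 29.6 percentage points higher from compound 2 to compound 3 (beyond the scatter). This change is small, since one chlorine atom gives way to a carbon and an oxygen, and the methoxy brings one hydrogen-bond acceptor that the chloro lacks, yet it moves the number further than the earlier step between the 2-nitrophenyl and 4-chlorophenyl compounds did. Compound 3 also separates from the 2-nitrophenyl compound, with a number 22.1 percentage points higher from compound 1 to compound 3 (beyond the scatter), so among these three compounds it gives the strongest effect at the one dose tested, whereas compound 1 and compound 2 remain within the scatter of each other.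

Three compounds cannot show whether the gain is specific to methoxy or would also appear with a hydroxy group, a longer ethoxy chain or a dimethylamino group at this place. Nothing at hand explains why methoxy gives the higher number, so the reason for this step stays open.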